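This account rests on a few compounds, and the source may have more. Where it says the series, first, only, none or still open, it means among the compounds named here.

Compound 1 `COc1cccc(-c2nc(SC)nc3sc(C(=O)NCCO)c(N)c23)c1`: 20.5%
Compound 2 `COc1cccc(-c2nc(SC)nc3sc(C(=O)NC(C)(C)C)c(N)c23)c1F`: 46.3%

In a functional assay on HEK293 cells for agonist activity at lutropin-choriogonadotropic hormone receptor (Homo sapiens), read by cAMP accumulation (a higher number here means a larger maximal response, a lower number a smaller maximal response), compound 1 gives 20.5%, the lower of the two measured values; compound 2 gives 46.3%, and that gap lies beyond the usual scatter. Compound 3 `COc1cccc(-c2nc(SC)nc3sc(C(=O)N(C)C)c(N)c23)c1` has not yet been tested. It differs from compound 1 in one place: dimethylamino in place of (2-hydroxyethyl)amino on a carbonyl carbon. Among the measured compounds shown here, no measured pair shows this exact change, so the expected step from compound 1 is small, a number 4.5 percentage points higher from compound 1 to compound 3 (within the scatter), and possibly none beyond the scatter. Compound 3 is therefore estimated to reach about 25%, within a range from 10% to 45%.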

Compound 3, largest response reached (reported as efficacy), in percent of the reference or control that the assay uses: 11%
Compound 3: middle estimate off by 14 percentage points, on the high side, within the range that was stated.
By their numbers in this assay, from the lowest: compounds 3 and 1 (each within the scatter of the next); then compound 2.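

In this assay, dimethylamino, which has 0 hydrogen-bond donors and 0 hydrogen-bond acceptors, replaces (2-hydroxyethyl)amino, which has 2 donors and 1 acceptor, on a carbonyl carbon, and the result is a number 9.5 percentage points lower from compound 1 to compound 3 (within the scatter) for this pair. This pair therefore gives no sign that the response depends on those donors or that acceptor at this position. No available evidence explains the outcome. Still open, from the compounds shown here alone, is whether a longer chain such as (3-hydroxypropyl)amino, or a ring amine such as morpholine, on the same carbonyl carbon would move the response beyond the scatter. The shown compounds also do not tell whether a carboxylic acid at this position would do so.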